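This account rests on a few compounds, and the source may have more. Where it says the series, first, only, none or still open, it means among the compounds named here.

Working notes on the series. In a physicochemical assay for solubility, with a stated time of 3 days, at pH 7 (a lower number here means a less soluble compound, a higher number a more soluble compound), compound 1 (`NC(=O)c1ccc2[nH]c(-c3ccc(OC4CCCNC4)cc3)nc2c1`) reads > 400000 nM as a limit of the assay, not a number. Among the compounds with values here, compound 2 (`Cc1ccc(CN2CCCCC2CCOc2ccc(-c3nc4cc(C(N)=O)ccc4[nH]3)cc2)cc1`) gives 97000 nM in this assay, and this is the only true number available so far. Compound 3 (`NC(=O)c1ccc2[nH]c(-c3ccc(OCCC4CCCCN4Cc4ccc(Cl)cc4)cc3)nc2c1`) has not been measured. It differs from compound 2 by chloro in place of methyl on an aromatic carbon, para to a large group, so that 4-methylbenzyl becomes 4-chlorobenzyl (chloro in place of methyl on an aromatic carbon). Within the data shown here, no step between measured compounds sizes this change, so no shift beyond the scatter is expected in this assay, and compound 2 at 97000 nM remains the anchor for that expectation. The expected step of a 1.3-fold lower number from compound 2 to compound 3 (0.11 log units; within the scatter) stays within the usual scatter. For compound 3 the estimate is 75000 nM, with an expected range from 30000 nM to 170000 nM in this read-out.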

Compound 3, solubility: 115000 nM
Beside the measured number, compound 3's estimate is 1.5-fold (0.19 log units) below it; measured number inside the range.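

In this assay, within the data shown here, this is the first sized step at this position: a 1.2-fold higher number from compound 2 to compound 3 (0.07 log units; within the scatter). Chloro in place of methyl on an aromatic carbon, para to a large group, thus leaves compound 2 and compound 3 within the scatter of each other, so 4-methylbenzyl and 4-chlorobenzyl cannot be told apart in this read-out on the basis of this single pair. Nothing measured here speaks to the reason for this step.

A single pair sizes a single change, so the reading does not extend to a methoxy group, a nitrile or a carboxylic acid at this place. On these data alone, it also remains open whether chloro in place of methyl would read the same with a longer chain between the shared core and the benzyl-bearing ring.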